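This account rests on a few compounds, and the source may have more. Where it says the series, first, only, none or still open, it means among the compounds named here.

Measured so far

Compound 1, `CNC(=O)/C=C/c1ccncc1-c1ccc2ccccc2c1`: in a functional assay on MCF7 cells (Homo sapiens) for inhibition, read by sulforhodamine B assay, with a stated time of 72 h (a lower number here means a stronger inhibitor of growth, a higher number a weaker inhibitor of growth), compound 1 gives 9340 nM.
Compound 2, `O=C(/C=C/c1ccncc1-c1ccc2cc[nH]c2c1)N1CCOCC1`: compound 2 gives only > 10000 nM, which is a limit of this assay and not a number.

Compound 1 therefore holds the only number shown in this assay ; the other value sits at the limit of > 10000 nM in this assay, at which 1 of the 2 values shown sits. Within the data shown here, no pair of measured compounds differing in a single place is available, so no measured step can be drawn on.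

Compound 3, `O=C(O)CCc1ccncc1-c1ccc2ccccc2c1`, has not yet been measured. It differs from compound 1 in one place: 2-carboxyethyl in place of 2-(methylcarbamoyl)ethenyl on an aromatic carbon. Among the measured compounds shown here, with no measured step of this kind to lean on, the change is expected to move the number only modestly, toward weaker inhibition of growth, and the expected step is a 1.5-fold higher number from compound 1 to compound 3 (0.18 log units; within the scatter). Compound 3 is thus estimated at 14000 nM, within a range from 5000 nM to 40000 nM, with a real chance that this assay reports only a limit for compound 3.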

Compound 3, concentration for 50% growth inhibition: > 10000 nM
Compound 3 was reported as a limit; the forecaster's own chance of this, stated with the estimate: 55%; the middle value does not contradict the limit.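

In this assay compound 3 gives > 10000 nM, which is a limit of the assay and not a number. Placing 2-carboxyethyl in place of 2-(methylcarbamoyl)ethenyl on this aromatic carbon, opposite the ring nitrogen, gives an at least 1.0-fold higher number from compound 1 to compound 3 (0.02 log units; that floor lies within the scatter), so the step fixes only a floor and shows no stronger inhibition of growth with the new group. This is the first reading at this position, and it adds to the values held at the limit: the limit of > 10000 nM in this assay, at which 2 of the 3 values shown sit.

Among these compounds, the true size of the step cannot be read, and the single swap leaves the loss of the double bond unseparated from the change of the end group. As far as these compounds go, a saturated 2-(methylcarbamoyl)ethyl chain and an amine at the same place would address what remains open.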